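A few compounds are considered here, and "the series" means these few. Any claim that something is new, unique, unknown or untested is made for them only; others in the source may bear on it.

Two compounds have been measured so far in an ADME assay on microsomes from liver (Rattus norvegicus) for metabolic stability; a higher number here means faster removal of the compound, a lower number slower removal:

- Compound 1 `CC(C)Oc1cc(Oc2ccc(S(C)(=O)=O)cc2)cc(-c2cccc(=O)[nH]2)c1` gives 349 mL/min/kg
- Compound 2 `Cc1cnc(-c2cc(Oc3ccc(S(C)(=O)=O)cc3)cc(OC(C)C)c2)[nH]c1=O` gives 189 mL/min/kg

Among the compounds with values here, compound 2 lies within the scatter of compound 1, the only other number available, so the two cannot be told apart. Compound 3 `Cc1cc(=O)[nH]c(-c2cc(Oc3ccc(S(C)(=O)=O)cc3)cc(OC(C)C)c2)n1` is the next to be measured. Its change from compound 2 is a group of 8 heavy atoms (5 carbon, 2 nitrogen, 1 oxygen; one six-membered aromatic ring with 2 hetero atoms) in place of a group of 8 heavy atoms (5 carbon, 2 nitrogen, 1 oxygen; one six-membered aromatic ring with 2 hetero atoms), on an aromatic carbon, and the two have the same atoms, joined differently. The change sits on an aromatic carbon of a six-membered aromatic ring of carbon only.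

Within the data shown here, one measured step bears on this, also an exchange of one ring group for another on an aromatic carbon: a 1.8-fold lower number from compound 1 to compound 2 (0.27 log units; within the scatter), within the scatter. Among the measured compounds shown here, no measured pair shows the same atoms joined differently, so no shift beyond the scatter is expected in this assay. The expected step is a 1.1-fold higher number from compound 2 to compound 3 (0.02 log units; within the scatter), within the scatter. Compound 3 is expected at 200 mL/min/kg, with an estimated range of 95 mL/min/kg to 400 mL/min/kg.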

Compound 3, clearance in the Rattus norvegicus assay: 96 mL/min/kg
Beside the measured number, compound 3's estimate is 2.1-fold (0.32 log units) above it; the measured number falls inside the stated range.
By their numbers in the Rattus norvegicus assay, from the lowest: compounds 3, 2 and 1 (each within the scatter of the next, the first and the last beyond it).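

In the Rattus norvegicus assay, compound 2 gives 189 mL/min/kg and compound 3 gives 96 mL/min/kg; joining the same atoms of the ring group differently gives a 2.0-fold lower number from compound 2 to compound 3 (0.29 log units; within the scatter) and so stays too small to separate the two arrangements. Even so, compound 3 is the first compound here to stand clearly apart from compound 1, with a 3.6-fold lower number from compound 1 to compound 3 (0.56 log units; beyond the scatter) for the exchange of ring groups, which shows that the group on this aromatic carbon can shift the number by more than the scatter. In a physicochemical assay for lipophilicity, using the shake flask method (a higher number here means a more lipophilic compound, a lower number a more polar compound), compound 2 gives 2.68 and compound 3 gives 2.43; the rearrangement gives a number 0.25 log units lower from compound 2 to compound 3 (within the scatter) and likewise does not separate the two arrangements.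

From the compounds shown here alone, whether a ring group carrying an amine or a carboxylic acid on this aromatic carbon would take the number further from that of compound 1 remains open. Nothing available explains the gap between compound 1 and compound 3.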